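A few compounds are considered here, and "the series" means these few. Any claim that something is new, unique, unknown or untested is made for them only; others in the source may bear on it.

Among the measured compounds shown here, in a functional assay (mast cells) for inhibition, with Rattus norvegicus as the target (a lower number here means that less compound is needed, a higher number that more compound is needed for the effect), only two compounds have numbers so far. Compound 1 `CC1CC/C(=N\Nc2cccc(Cl)c2)c2ncc(C(=O)O)c(=O)n21` gives 311000 nM, while compound 2 `CC1CC/C(=N\Nc2ccc(O)cc2)c2ncc(C(=O)O)c(=O)n21` gives 1300 nM, the lowest number measured. Compound 3 `COc1ccc(N/N=C2\CCC(C)n3c2ncc(C(=O)O)c3=O)cc1` has the same core as compound 2 and differs from it in one place: methyl in place of hydrogen on an oxygen on an aromatic ring. This is methyl in place of hydrogen on an oxygen on an aromatic ring, which turns 4-hydroxyphenyl into 4-methoxyphenyl.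

For the measured compounds named here, only one measured step bears on this change: a 240-fold lower number from compound 1 to compound 2 (2.38 log units; beyond the scatter), a large step in which 4-hydroxyphenyl took the place of 3-chlorophenyl on an amine nitrogen. It shows that a change on this phenyl ring can move the number far. However, it replaced a different group, and no measured compound carries a methoxy, so its size is only a loose guide. Starting from the lower value of compound 2 at 1300 nM, a moderate rise is expected, well short of the measured step. The expected change is a 2.7-fold higher number from compound 2 to compound 3 (0.43 log units; beyond the scatter). For compound 3 the estimate is 3500 nM, with an expected range of 500 nM to 30000 nM.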

Compound 3, half-maximal effective concentration: 128000 nM
Beside the measured number, compound 3's estimate is 37-fold (1.56 log units) below it; measured number outside the range, above it.
By their numbers in this assay, from the lowest: compound 2; then compound 3; then compound 1.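

In this assay, among the compounds shown here, the earlier compounds showed that a change on this phenyl ring can move the number far, but they could not separate the oxygen from the hydrogen it carries. Compound 3 does: methyl in place of hydrogen on this oxygen, a single added heavy atom, gives a 98-fold higher number from compound 2 to compound 3 (1.99 log units; beyond the scatter), so the low number of compound 2 depends on the hydroxy itself and not merely on having an oxygen on the ring. The 4-methoxyphenyl group stays much nearer to the 3-chlorophenyl group, with a 2.4-fold lower number from compound 1 to compound 3 (0.39 log units; beyond the scatter), a modest step though still beyond the scatter, and nothing here accounts for the size of either step.

From the compounds shown here alone, what remains open is whether another group at this place on the ring, such as an amine or a carboxylic acid, could keep a number as low as that of compound 2, and whether a longer chain on the oxygen, such as ethoxy, would raise it further. Going by these compounds, it is equally open whether the hydroxy would give a similar number elsewhere on the ring, as in 3-hydroxyphenyl.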